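The source may hold more compounds than are shown below. What is called first, only, known or untested is meant among the compounds shown, and "the series" means these compounds.

Compound 1, `O=C(c1cccc(Cl)c1)N1CCn2nc(-c3ccc(F)cn3)cc2C1`: 150 nM
Compound 2, `N#Cc1cccc(C(=O)N2CCn3nc(-c4ccc(F)cn4)cc3C2)c1`: > 10000 nM

Of the two measured compounds, compound 1 gives 150 nM in a functional assay on HEK293 cells for negative allosteric modulation of metabotropic glutamate receptor 5 (Homo sapiens), read by calcium flux, with a stated time of 20 min; on this read-out lower numbers stand for stronger inhibition and higher numbers for weaker inhibition. Going by these compounds, compound 2 reaches only a limit of the assay, > 10000 nM, so its true value is unknown (the limit of > 10000 nM in this assay, at which 1 of the 2 values shown sits). Among the measured compounds shown here, the one measured step, an at least 66-fold higher number from compound 1 to compound 2 (1.82 log units; beyond the scatter), is therefore the only guide to what the group on this aromatic carbon does.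

Compound 3, `O=C(c1cccc(C(F)(F)F)c1)N1CCn2nc(-c3ccc(F)cn3)cc2C1`, has not yet been measured. It differs from compound 2 by trifluoromethyl in place of cyano on an aromatic carbon. The step from compound 1 to compound 2 shows that exchanging the group at this position can move the number very far, so a large step in either direction is possible here. Compound 3 is expected to return some way toward the value of compound 1, giving an estimate of 600 nM with a range from 120 nM to 6000 nM, which would mean an expected step of an at least 16-fold lower number from compound 2 to compound 3 (1.22 log units; beyond the scatter).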

Compound 3, half-maximal inhibitory concentration: 383 nM
Estimate against measurement, compound 3: 1.6-fold (0.19 log units) above; the range from low to high includes it.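

Activity at this aromatic carbon is not tied to chloro: trifluoromethyl in place of cyano brings back a measurable value, with an at least 26-fold lower number from compound 2 to compound 3 (1.41 log units; beyond the scatter) and no loss on the scale seen for the nitrile. Set against chloro, trifluoromethyl still gives up some inhibition, with a 2.6-fold higher number from compound 1 to compound 3 (0.41 log units; beyond the scatter) as a real but smaller separation between two groups that both leave compound 1 and compound 3 active. The first of these steps is only a bound, since compound 2 stands at a limit of the assay: the limit of > 10000 nM in this assay, at which 1 of the 3 values shown sits.

The three compounds leave open whether the loss belongs to the nitrile alone or extends to other groups on this carbon, such as methoxy, an amine or a carboxylic acid. They also do not show how chloro or trifluoromethyl would behave on other carbons of this ring.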